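This account rests on a few compounds, and the source may have more. Where it says the series, first, only, none or still open, it means among the compounds named here.

In a functional assay on A549 cells (Homo sapiens) for antiproliferative activity, read by MTT assay, with a stated time of 72 h (on this read-out higher numbers stand for weaker inhibition and lower numbers for stronger inhibition), compound 1 (`CC(C)N1C(=O)COc2ccc(-c3cnc(Cl)c(NS(=O)(=O)c4ccc(F)cc4)c3)cc21`) gives 5100 nM and compound 2 (`COc1ncc(-c2ccc3c(c2)N(c2ccccc2)C(=O)CO3)cc1NS(=O)(=O)c1ccc(F)cc1`) gives 3490 nM, while compound 3 (`Cc1ccc(N2C(=O)COc3ccc(-c4cnc(Cl)c(NS(=O)(=O)c5ccc(F)cc5)c4)cc32)cc1`) gives 30900 nM as the highest number of the three, which means the weakest inhibition. Compound 4 (`O=C1COc2ccc(-c3cnc(Cl)c(NS(=O)(=O)c4ccc(F)cc4)c3)cc2N1c1ccccc1`) differs from compound 3 by a single change (hydrogen in place of methyl on an aromatic carbon), hydrogen in place of methyl on an aromatic carbon. For the measured compounds named here, the only measured step that bears on it is a modest one, a 6.1-fold higher number from compound 1 to compound 3 (0.78 log units; beyond the scatter) as 4-methylphenyl replaces isopropyl. Compound 2 also carries a phenyl, but it differs elsewhere too. Going by the values given here, a modest move to a lower number, no larger than that step, is therefore expected in this assay. The expected change is a 3.1-fold lower number from compound 3 to compound 4 (0.49 log units; beyond the scatter) as a gain in inhibition. Compound 4 is estimated at 10000 nM (range 3500 nM to 28000 nM).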

Compound 4, half-maximal inhibitory concentration: 14700 nM
Compound 4: middle estimate off by 1.5-fold (0.17 log units), on the low side; measured number inside the range.
By their numbers in this assay, from the lowest: compounds 2 and 1 (each within the scatter of the next); then compound 4; then compound 3.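

In this assay, losing the methyl from the 4-methylphenyl group brings a modest gain, a 2.1-fold lower number from compound 3 to compound 4 (0.32 log units; beyond the scatter), yet the phenyl group still falls short of isopropyl on the ring nitrogen, a 2.9-fold higher number from compound 1 to compound 4 (0.46 log units; beyond the scatter), so only part of the loss seen with compound 3 comes back. With phenyl held constant, the other ring substituent also counts, as chloro in place of methoxy gives a 4.2-fold higher number from compound 2 to compound 4 (0.62 log units; beyond the scatter). Nothing shown explains either shift. Open, from the compounds shown here alone, is how an amine or a carboxylic acid would behave in place of that methyl, and whether a longer chain on the ring nitrogen would match isopropyl.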